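A few compounds are considered here, and "the series" means these few. Any claim that something is new, unique, unknown or untested is made for them only; others in the source may bear on it.

In a functional assay on A-375 cells (Homo sapiens) for antiproliferative activity, read by MTT assay, with a stated time of 72 h (on this read-out higher numbers stand for weaker inhibition and lower numbers for stronger inhibition), three compounds have been read, and they differ only in the group on an amide-type nitrogen in a ring. Compound 1 (`COc1cccc(N2C(=O)COc3ccc(-c4cnc(Cl)c(NS(=O)(=O)c5ccc(F)cc5)c4)cc32)c1`), with 3-methoxyphenyl there, gives only a limit of the assay, > 40000 nM. Compound 2 (`O=C1COc2ccc(-c3cnc(Cl)c(NS(=O)(=O)c4ccc(F)cc4)c3)cc2N1C1CCCCC1`), with cyclohexyl there, also gives only a limit, > 40000 nM. For the measured compounds named here, compound 3 (`CC(C)N1C(=O)COc2ccc(-c3cnc(Cl)c(NS(=O)(=O)c4ccc(F)cc4)c3)cc21`), with isopropyl, gives 25500 nM, the only true number among the three. The rest of the readings sit at the limit of > 40000 nM in this assay, at which 2 of the 3 values shown sit.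

Compound 4 (`O=C1COc2ccc(-c3cnc(Cl)c(NS(=O)(=O)c4ccc(F)cc4)c3)cc2N1c1ccc(F)cc1`) carries 4-fluorophenyl in place of the isopropyl of compound 3: 4-fluorophenyl in place of isopropyl on an amide-type nitrogen in a ring. Going by the values given here, two measured steps bear on this change, an at least 1.5-fold lower number from compound 1 to compound 3 (0.19 log units; that floor lies within the scatter) and an at least 1.5-fold lower number from compound 2 to compound 3 (0.19 log units; that floor lies within the scatter), and each is known only as a floor. The former lies closer, as it also exchanges a substituted phenyl and isopropyl, though here the change runs the opposite way. On that reading, the number in this assay should rise modestly toward the limit, and a report of a limit alone would be no surprise. Expected in this assay is a 1.5-fold higher number from compound 3 to compound 4 (0.17 log units; within the scatter), a move toward weaker inhibition that may not clear the scatter. Compound 4 is estimated at 38000 nM, with an expected range of 20000 nM to 70000 nM.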

Compound 4, half-maximal inhibitory concentration: > 40000 nM
Compound 4 ended at the assay's limit (the forecaster's own chance of this, stated with the estimate: 55%); at least 1.0-fold (0.02 log units) between middle value and limit.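

In this assay, 4-fluorophenyl in place of isopropyl on the amide-type nitrogen in a ring gives an at least 1.5-fold higher number from compound 3 to compound 4 (0.19 log units; that floor lies within the scatter), so this change is known only as a floor. For the compounds shown here, with compound 4, a fluorine-bearing phenyl joins the 3-methoxyphenyl of compound 1 and the cyclohexyl of compound 2 at the limit, and the isopropyl of compound 3 remains the only group at this position with a true number: the limit of > 40000 nM in this assay, at which 3 of the 4 values shown sit. The steps from compound 2 to compound 4 and from compound 1 to compound 4 cannot be read, as both ends of each are limits.

The compounds shown leave open whether the true readings of compound 1, compound 2 and compound 4 differ from one another, and whether the true step from compound 3 to compound 4 clears the scatter. They also leave open what a plain hydrogen, a methyl, an ethyl or a chain ending in an amine on this nitrogen would give in this assay.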